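From Chloro to Methyl on the Shared Core

A few compounds are considered here, and "the series" means these few. Any claim that something is new, unique, unknown or untested is made for them only; others in the source may bear on it.

Two compounds have been read in a functional assay on MDA-MB-435S cells (Homo sapiens) for antiproliferative activity, read by MTT assay, with a stated time of 72 h; on this read-out higher numbers stand for weaker inhibition and lower numbers for stronger inhibition:
compound 1 `Cc1ccc2c(=O)c(CSC(=S)N(C(C)C)C(C)C)coc2c1`: 240 nM
compound 2 `O=c1c(CSC(=S)N2CCOCC2)coc2cc(Cl)ccc12`: 600 nM

Of these two numbers compound 2 stands highest, and its gap to compound 1 lies beyond the scatter. Compound 3 `Cc1ccc2c(=O)c(CSC(=S)N3CCOCC3)coc2c1` is still unmeasured and differs from compound 2 in one place: methyl in place of chloro on an aromatic carbon. Among the measured compounds shown here, compound 1 also bears a methyl rather than chloro, yet it differs elsewhere too, so no clean step for this change is available. For compound 3 the expected step is a 1.5-fold lower number from compound 2 to compound 3 (0.18 log units; within the scatter), a modest lowering near the edge of the scatter. Compound 3 is therefore estimated at 400 nM, within 150 nM to 1000 nM.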

Compound 3, half-maximal inhibitory concentration: 5500 nM
Beside the measured number, compound 3's estimate is 14-fold (1.14 log units) below it, outside the stated range (above it).
By their numbers in this assay, from the lowest: compound 1; then compound 2; then compound 3.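

In this assay this aromatic carbon proves sensitive: methyl in place of chloro gives a 9.2-fold higher number from compound 2 to compound 3 (0.96 log units; beyond the scatter) and so the two groups are not interchangeable here. Compound 3 also isolates the group on the thiocarbonyl carbon, where morpholin-4-yl in place of diisopropylamino gives a 23-fold higher number from compound 1 to compound 3 (1.36 log units; beyond the scatter) on the methyl-bearing core. Nothing at hand gives a reason for either step. The compounds shown leave open how a fluoro or methoxy group would read at this aromatic carbon. They also leave open how chloro and diisopropylamino would read together on the shared core.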